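Swapping Trifluoromethyl for Fluoro on the Sulfonyl Aryl Ring

The compounds below may be only part of what the source reports. "The series", "measured", "known", "first", "only" and "open" are said of these compounds alone.

Four compounds are considered here. Compound 1 `O=C1/C(=C/c2ccccc2F)CN(S(=O)(=O)c2ccc(C(F)(F)F)cc2)C/C1=C\c1ccccc1F` and compound 2 `O=C1/C(=C/c2ccccc2F)CN(S(=O)(=O)c2ccc(F)cc2)C/C1=C\c1ccccc1F` are built on one core, while compound 3 `O=C1/C(=C/c2cccc(F)c2)CN(S(=O)(=O)c2ccc(C(F)(F)F)cc2)C/C1=C\c1cccc(F)c1` and compound 4 `O=C1/C(=C/c2cccc(F)c2)CN(S(=O)(=O)c2ccc(F)cc2)C/C1=C\c1cccc(F)c1` are built on another; the difference between the two cores is not broken down here. In an ADME assay on L02 cells (Homo sapiens) for cytotoxicity, read by MTT assay, with a stated time of 24 h (a higher number here means a weaker inhibitor, a lower number a stronger inhibitor), compound 1 gives 16200 nM and compound 2 gives 17500 nM. In this assay compound 3 gives 18000 nM, a number that sits within the usual scatter of both compound 1 and compound 2, so no order among the three can be read from these figures.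

The change that separates compound 1 from compound 2 is fluoro in place of trifluoromethyl on an aromatic carbon. Its effect in this assay is a 1.1-fold higher number from compound 1 to compound 2 (0.03 log units; within the scatter), which means the number did not move in any way that can be told apart from repeat-to-repeat noise.

Compound 4 has not yet been measured. It differs from compound 3 by fluoro in place of trifluoromethyl on an aromatic carbon. Going by the values given here, this is the same change as the one from compound 1 to compound 2, made at the same place on the same kind of ring, only on the other core. In this assay the step is expected to be a 1.1-fold higher number from compound 3 to compound 4 (0.02 log units; within the scatter), because the matching step a 1.1-fold higher number from compound 1 to compound 2 (0.03 log units; within the scatter) stayed within the scatter. On that basis compound 4 is expected to give 19000 nM in this assay. The estimate for compound 4 is expected to lie between 9500 nM and 38000 nM.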

Compound 4, half-maximal inhibitory concentration: 21900 nM
The estimate for compound 4 lay 1.2-fold (0.06 log units) below the measured number, and the stated range covers the measured number.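

In this assay, putting fluoro in place of trifluoromethyl on the 4-(trifluoromethyl)phenyl group of compound 3 gives a 1.2-fold higher number from compound 3 to compound 4 (0.09 log units; within the scatter), so on this core, too, the two numbers cannot be told apart from repeat-to-repeat noise. Set side by side, the two steps agree, and the size of the swap's effect on one core cannot be distinguished from its size on the other: the same change on two cores in this assay, a 1.1-fold higher number (0.03 log units; within the scatter) from compound 1 to compound 2 and a 1.2-fold higher number (0.09 log units; within the scatter) from compound 3 to compound 4, 1.1-fold (0.05 log units) apart, within the scatter of two such steps. This shows that in these two pairs the swap leaves no readable mark on the number on either core, but it does not show that a step with a real, measurable effect would carry from one core to the other, and two cores cannot establish a rule for the wider series.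

Still open, going by these compounds, is whether an amine or a carboxylic acid at the place held by trifluoromethyl and fluoro would give a step beyond the scatter in this assay, and whether such a step would then be the same size on both cores. Also open, on these data alone, is whether the fluoro-for-trifluoromethyl swap would stay within the scatter on a core with methoxy groups in place of the fluoro groups on its benzylidene rings.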